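Thiourea in Place of Benzyl on a Fused Ring Amine

A few compounds are considered here, and "the series" means these few. Any claim that something is new, unique, unknown or untested is made for them only; others in the source may bear on it.

The measured compounds, all in a functional assay on HeLa cells (Homo sapiens) for antiproliferative activity, with a stated time of 24 h; a higher number here means a weaker inhibitor, a lower number a stronger inhibitor:
Compound 1 `N#Cc1ccccc1CN1CCc2c(sc(NC(=O)c3ccccc3Cl)c2C(N)=O)C1` gives > 50000 nM, a limit of the assay and not a number.
Compound 2 `NC(=O)c1c(NC(=O)c2ccccc2Cl)sc2c1CCN(C(=S)Nc1cccc3ccccc13)C2` gives 30800 nM.
Compound 3 `CSc1ccccc1NC(=S)N1CCc2c(sc(NC(=O)c3ccccc3Cl)c2C(N)=O)C1` gives 43600 nM.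

Compound 1 therefore stands only at a bound: of the three values shown, it is the one sitting at the limit of > 50000 nM in this assay, at which 1 of the 3 values shown sits, while compound 2 and compound 3 each give a number. Compound 4 `COc1ccc(NC(=S)N2CCc3c(sc(NC(=O)c4ccccc4Cl)c3C(N)=O)C2)cc1` differs from compound 1 in that (a group of 11 heavy atoms (8 carbon, 1 nitrogen, 1 oxygen, 1 sulfur; one six-membered aromatic ring of carbon only) in place of a group of 9 heavy atoms (8 carbon, 1 nitrogen; one six-membered aromatic ring of carbon only), on an amine nitrogen in a ring). Within the data shown here, two measured steps bear on this change. The step of an at least 1.1-fold lower number from compound 1 to compound 3 (0.05 log units; that floor lies within the scatter) likewise exchanges the 2-cyanobenzyl on the amine nitrogen in a ring for a thiourea-bearing aryl group, and its floor lies within the scatter. The step of a 1.4-fold higher number from compound 2 to compound 3 (0.15 log units; within the scatter) exchanges one aryl on the amide-type nitrogen for another and is also within the scatter. Compound 4 is therefore expected to give a number close to those of compound 2 and compound 3, so the expected step of an at least 1.2-fold lower number from compound 1 to compound 4 (0.09 log units; that floor lies within the scatter) is estimated to be small. The estimate for compound 4 is 40000 nM, with a range from 18000 nM to 90000 nM.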

Compound 4, half-maximal inhibitory concentration: 36400 nM
The estimate for compound 4 lay 1.1-fold (0.04 log units) above the measured number; the measured number falls inside the stated range.
By their numbers in this assay, from the lowest: compounds 2, 4 and 3 (each within the scatter of the next). At a limit, above all of these: compound 1.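

Replacing the aryl group on the amide-type nitrogen with 4-methoxyphenyl gives no change beyond the scatter in this assay (from the 2-(methylsulfanyl)phenyl compound: a 1.2-fold lower number from compound 3 to compound 4 (0.08 log units; within the scatter); from the naphthalen-1-yl compound: a 1.2-fold higher number from compound 2 to compound 4 (0.07 log units; within the scatter)), so these three aryl groups cannot be told apart at this place. The exchange of 2-cyanobenzyl on the amine nitrogen in a ring for the group in compound 4 can be read only as a floor (it is an at least 1.3-fold lower number from compound 1 to compound 4 (0.13 log units; that floor lies within the scatter)), so it shows no firm gain. Compound 1 stands at a limit of the assay and not at a number: the limit of > 50000 nM in this assay, at which 1 of the 4 values shown sits.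

Going by these compounds, how far the step from compound 1 really reaches remains open. On these data alone, it is also open how a urea in place of the thiourea, or an aryl group carrying an amine or a carboxylic acid, would read in this assay.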